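Chloro in Place of Trifluoromethyl: What to Expect

A few compounds are considered here, and "the series" means these few. Any claim that something is new, unique, unknown or untested is made for them only; others in the source may bear on it.

Measured so far:
Compound 1 `O=C(/C=C/c1ccc(O)c(O)c1)NCc1ccccc1C(F)(F)F` gives 22%
Compound 2 `O=C(/C=C/c1ccc(O)c(O)c1)NCc1ccc(C(F)(F)F)cc1` gives 26%

Both numbers come from an ADME assay on B16 cells (Mus musculus) for cytotoxicity, read by MTT assay, tested at 5 uM; a higher number here means a stronger effect of the compound at the concentration tested, a lower number a weaker effect. In this assay compound 1 gives 22%, while compound 2 gives 26%. Compound 2 has the higher of the two numbers, yet the gap between it and compound 1 lies within the usual scatter, so the two read as the same, and both are modest effects at this concentration.

Compound 3 `O=C(/C=C/c1ccc(O)c(O)c1)NCc1ccc(Cl)cc1` is not yet measured. It differs from compound 2 in one place: chloro in place of trifluoromethyl on an aromatic carbon. For the measured compounds named here, no step between two measured compounds exists here to show how this assay answers such a swap, so nothing in the data points to a move beyond the scatter. The expected step is a number 1 percentage points lower from compound 2 to compound 3 (within the scatter). Compound 3 is therefore estimated at 25%, with a range from 12% to 38%.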

Compound 3, a percentage reported as activity, at one concentration (the size of the read-out at that concentration, not a potency): 23%
Compound 3: the middle estimate sits 2 percentage points above what was measured, and the stated range covers the measured number.
By their numbers in this assay, from the lowest: compounds 1, 3 and 2 (each within the scatter of the next).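

In this assay chloro in place of trifluoromethyl gives a number 3 percentage points lower from compound 2 to compound 3 (within the scatter) and so the two compounds read as the same. For the compounds shown here, this is the first step showing how this assay answers a change at this place, on an aromatic carbon para to a large group: a single chlorine atom can stand where four heavy atoms stood, with no difference that the assay can separate from scatter at this one concentration. The data offer no explanation for this sameness.

Still open, as far as these compounds go, is whether a group of another kind, such as an amine, a carboxylic acid or a longer chain, would also read the same at this place. Also open, from the compounds shown here alone, is whether chloro would match trifluoromethyl at the place that group holds in compound 1.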